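Swapping an aryloxy link for a direct aryl bond

This account rests on a few compounds, and the source may have more. Where it says the series, first, only, none or still open, it means among the compounds named here.

Measured compounds in a physicochemical assay for solubility, with a stated time of 18 h, at pH 7.4; a higher number here means a more soluble compound, a lower number a less soluble compound:
- compound 1 `COc1ccc(Oc2ccc3c(NCCCNCc4cc(F)ccc4OC)ccnc3c2)cc1`, compound 1 gives 14500 nM
- compound 2 `COc1ccc(Oc2ccc3c(NCCCNCc4cccc(OC)c4O)ccnc3c2)cc1`, compound 2 gives 14500 nM
- compound 3 `COc1cccc(CNCCCNc2ccnc3cc(-c4ccccc4)ccc23)c1O`, compound 3 gives 32000 nM

Compound 1 sits level with compound 2, and together they hold the lowest solubility of the three numbers: the step of no change at the digits printed from compound 1 to compound 2 (within the scatter) changes nothing beyond the scatter. Compound 3 stands apart, since the step of a 2.2-fold higher number from compound 2 to compound 3 (0.34 log units; beyond the scatter) raised solubility modestly.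

The unmeasured compound 4 `COc1ccc(-c2ccc3c(NCCCNCc4cc(F)ccc4OC)ccnc3c2)cc1` is reached from compound 1 by a single change: 4-methoxyphenyl in place of 4-methoxyphenoxy on an aromatic carbon. Among the measured steps, only the one from compound 2 to compound 3 bears on this, since it also replaced 4-methoxyphenoxy on an aromatic carbon of the shared core, and it produced a 2.2-fold higher number from compound 2 to compound 3 (0.34 log units; beyond the scatter). The change into compound 4 keeps a methoxy group that compound 3 lacks, so the comparison is loose, and a step of about that size, or none beyond the scatter, is the reasonable expectation.

On that basis the solubility of compound 4 is expected to be 22000 nM, with a range from 9000 nM to 50000 nM, an estimated step of a 1.5-fold higher number from compound 1 to compound 4 (0.18 log units; within the scatter).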

Compound 4, solubility: 32000 nM
Estimate against measurement, compound 4: 1.5-fold (0.16 log units) below; the measured number falls inside the stated range.
By their numbers in this assay, from the lowest: compounds 1 and 2 (each within the scatter of the next); then compounds 3 and 4 (each within the scatter of the next).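

At this aromatic carbon of the shared core, exchanging the 4-methoxyphenoxy group for 4-methoxyphenyl gives a 2.2-fold higher number from compound 1 to compound 4 (0.34 log units; beyond the scatter) in this assay, a modest step in which the entering ring keeps its methoxy group and the group as a whole has one oxygen where the leaving group has two. Going by these compounds alone, the only earlier step at this position, a 2.2-fold higher number from compound 2 to compound 3 (0.34 log units; beyond the scatter), ended in an unsubstituted phenyl, so it could not separate removing the linking oxygen from removing the methoxy group as well, whereas the new step is printed at the same size with the methoxy group still in place, on a compound with a different group at the far end of the chain. Nothing shown here offers a measured cause for this higher number.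

The compounds shown do not tell how a basic amine such as morpholine, or a carboxylic acid, would read on this same aromatic carbon. They also leave open whether a longer chain between the two nitrogens would alter the number when 4-methoxyphenyl is in place.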